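This account rests on a few compounds, and the source may have more. Where it says the series, first, only, none or still open, it means among the compounds named here.

Three compounds share one core and differ only in the group that sits on the six-membered aromatic ring of carbon only. In an assay on HEK293 cells for agonist activity at transient receptor potential cation channel subfamily M member 8 (Homo sapiens), read by fluorescence and calcium flux, with a stated time of 15 min (on this read-out higher numbers stand for an effect only at larger amounts of compound and lower numbers for an effect already at smaller amounts), compound 1 `CCCc1ccc(OCC(=O)N(CC)Cc2cccs2)cc1` gives 1810 nM, compound 2 `CCN(Cc1cccs1)C(=O)COc1ccc(Cl)cc1` gives 39 nM, and compound 3 `CCN(Cc1cccs1)C(=O)COc1ccc(OC)cc1` gives 120 nM. Compound 3 holds the second highest number of the three, with a 3.1-fold higher number from compound 2 to compound 3 (0.49 log units; beyond the scatter) as the nearest step and a 15-fold lower number from compound 1 to compound 3 (1.18 log units; beyond the scatter) as the furthest. Compound 4 `CCN(Cc1cccs1)C(=O)COc1ccc(CO)cc1` arises from compound 3 by hydroxymethyl in place of methoxy on an aromatic carbon. Going by the values given here, no measured step involves hydroxymethyl, so the two exchanges at this position, one modest and one large, only frame the likely size. The expected step is a 2.5-fold higher number from compound 3 to compound 4 (0.40 log units; beyond the scatter), toward a higher number. In this assay compound 4 is estimated at 300 nM, with a range from 100 nM to 900 nM.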

Compound 4, half-maximal effective concentration: 21900 nM
The estimate for compound 4 lay 73-fold (1.86 log units) below the measured number; the measured number lies above the stated range.
By their numbers in this assay, from the lowest: compound 2; then compound 3; then compound 1; then compound 4.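

In this assay the same atoms, rearranged from methoxy to hydroxymethyl, give a 180-fold higher number from compound 3 to compound 4 (2.26 log units; beyond the scatter) at this position, so an exchange that adds no heavy atom can outweigh every earlier step here. Hydroxymethyl also stands apart from chloro, with a 560-fold higher number from compound 2 to compound 4 (2.75 log units; beyond the scatter) and from propyl, with a 12-fold higher number from compound 1 to compound 4 (1.08 log units; beyond the scatter) and thus the highest number of the four. The exchange adds one hydrogen-bond donor, but nothing available here links that count or any other feature to the result. On these data alone, whether the rise follows the hydroxy itself or its carbon link to the ring stays open. A plain hydroxy, an amine, a carboxylic acid or a longer chain ending in hydroxy at this position would bear on that.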